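Swapping Chloro for Fluoro on the Aryl Hydrazone

The compounds below may be only part of what the source reports. "The series", "measured", "known", "first", "only" and "open" are said of these compounds alone.

Three hydrazone-type compounds have been tested in a functional assay on IMR-32 cells (Homo sapiens) for inhibition, read by sulforhodamine B assay, with a stated time of 48 h; on this read-out higher numbers stand for weaker inhibition of growth and lower numbers for stronger inhibition of growth. Compound 1, `COc1ccc(/C=N\NC(=O)C2=C(Cl)c3ccccc3CCC2)c(OC)c1`, gives 14900 nM. Compound 2, `Cc1cc2c(cc1C)C(Cl)=C(/C=N\NC(=O)C1=C(Cl)c3ccccc3CCC1)CCC2`, gives 670 nM, the lowest of the three numbers. Compound 3, `Cc1cc2c(cc1C)C(Cl)=C(C(=O)N/N=C\c1ccc(Cl)cc1)CCC2`, gives 18300 nM, the highest of the three numbers; compound 1 sits within the usual scatter of it, while compound 2 lies well beyond the scatter, with a clearly lower number. So compound 3 and compound 1 cannot be told apart on these numbers, and only compound 2 stands clearly apart from both.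

The next compound, compound 4, `Cc1cc2c(cc1C)C(Cl)=C(C(=O)N/N=C\c1ccc(F)cc1)CCC2`, differs from compound 3 in one place: fluoro in place of chloro on an aromatic carbon. Nothing else in the molecule moves. Within the data shown here, no measured pair in this set shows what this exchange does, so the step from compound 3 to compound 4 has to be judged without a precedent. A halogen is replaced by a halogen, no donor or acceptor is gained or lost, and no ring changes. The expectation is therefore a step of a 1.1-fold higher number from compound 3 to compound 4 (0.04 log units; within the scatter) in this assay, that is, no change beyond the scatter, with at most a mild drift toward a higher number. On that basis compound 4 is estimated at 20000 nM, within a range from 8000 nM to 50000 nM.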

Compound 4, concentration for 50% growth inhibition: 3500 nM
Estimate against measurement, compound 4: 5.7-fold (0.76 log units) above; the measured number lies below the stated range.
By their numbers in this assay, from the lowest: compound 2; then compound 4; then compounds 1 and 3 (each within the scatter of the next).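

In this assay, the change from 4-chlorophenyl to 4-fluorophenyl gives a 5.2-fold lower number from compound 3 to compound 4 (0.72 log units; beyond the scatter), so this place on the aromatic ring is not indifferent to which halogen it carries, even though only one heavy atom is exchanged and no hydrogen-bond donor, hydrogen-bond acceptor or ring is gained or lost. Among these compounds, the earlier compounds could not show this: they differ from one another in more than one place, which left no single position open to a direct reading, and this pair is the first in the set where one exchange can be followed on its own. The measurements at hand offer nothing that explains the size of this step, so it stands here as an observation only.

From the compounds shown here alone, what remains open is whether bromo, an amine or a plain hydrogen at this same place would move the number further down, back up or not at all. A single pair also leaves open whether the same exchange would give a step of similar size on a different core, so it sets no general rule for this change.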